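This account rests on a few compounds, and the source may have more. Where it says the series, first, only, none or still open, it means among the compounds named here.

Measured in a functional assay on MDA-MB-231 cells (Homo sapiens) for cytotoxicity, read by MTT assay, with a stated time of 72 h; a higher number here means a weaker inhibitor, a lower number a stronger inhibitor:
- compound 1 `O=C1c2c[n+]([O-])c3ccccc3c2C(=O)c2c1c1ccccc1n2Cc1cn([C@H]2O[C@H](CO)[C@@H](O)[C@H]2O)nn1`: 1700 nM
- compound 2 `O=C1c2c[n+]([O-])c3ccccc3c2C(=O)c2c1c1ccccc1n2CCN1CCCC1`: 630 nM

Compound 1 holds the higher of the two numbers, and the gap down to compound 2 lies beyond the scatter. Not yet measured is compound 3 `CC1(C)OC[C@@H](Cn2cc(Cn3c4c(c5ccccc53)C(=O)c3c[n+]([O-])c5ccccc5c3C4=O)nn2)O1`, which keeps the core of compound 1 and the five-membered aromatic ring with 3 nitrogen. The change is (2,2-dimethyl-1,3-dioxolan-4-yl)methyl in place of 3,4-dihydroxy-5-(hydroxymethyl)oxolan-2-yl on an aromatic nitrogen.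

Among the measured compounds shown here, no measured pair differs in one place, so the data give no direct size for such a change. Compound 2, at 630 nM, shows the same core reaching a lower number with another side chain, and this is the only support for expecting a move in that direction in this assay. The support is thin, so only a modest move is expected, possibly one within the scatter. The estimated change is a 1.7-fold lower number from compound 1 to compound 3 (0.23 log units; within the scatter). For compound 3 the expected value is 1000 nM, with an estimated range of 350 nM to 2800 nM.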

Compound 3, half-maximal inhibitory concentration: > 1000 nM
Compound 3: a limit, no number (the forecaster's own chance of this, stated with the estimate: 3%); the middle value lies on the limit itself.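

In this assay compound 3 gives > 1000 nM, which is a limit and not a number. No step can be read between compound 1 and compound 3. The compounds shown leave open whether (2,2-dimethyl-1,3-dioxolan-4-yl)methyl in place of 3,4-dihydroxy-5-(hydroxymethyl)oxolan-2-yl changes the number in this assay at all, and in which direction.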